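The source may report more compounds than this note shows. Statements on the series, on what has been measured and on what is new or still open speak of the compounds shown alone.

Compounds in the series: compound 1 `O=C(Nc1cc(-c2ccccn2)n[nH]1)N1CCC(c2ccc(Cl)cc2)CC1`, compound 2 `O=C(Nc1cc(-c2ccccn2)n[nH]1)N1CCC(Oc2ccccc2)CC1`, compound 3 `O=C(NCc1ccccc1)Nc1[nH]nc(-c2ccccn2)c1Cl` and the not yet measured compound 4 `O=C(Nc1cc(-c2ccccn2)n[nH]1)N1CCC(Oc2ccccn2)CC1`. In an ADME assay on cells (Peritoneal macrophage cell, Mus musculus) for cytotoxicity, read by fluorescence and resazurin assay, with a stated time of 3 days (a lower number here means that less compound is tolerated, a higher number that more compound is tolerated), compound 1 gives only a limit, > 55000 nM. Compound 2 likewise gives only a limit in this assay, > 40000 nM. Compound 3 also gives only a limit in this assay, > 64000 nM. Within the data shown here, every value so far is a limit, so compound 2 stands level with the others as far as the numbers allow, and the one step between measured compounds, a step that the two limits leave unreadable from compound 1 to compound 2, is of unknown size. Compound 4 differs from compound 2 by pyridin-2-yl in place of phenyl on an oxygen on a saturated carbon. Among the measured compounds shown here, no measured step covers this change, and no step beyond the scatter is expected in this assay. Compound 4 is therefore expected to give 50000 nM (range 30000 nM to 80000 nM). The expected step is a step that the limit leaves unreadable from compound 2 to compound 4, most likely hidden again behind a limit.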

Compound 4, half-maximal cytotoxic concentration: > 64000 nM
Compound 4 was reported as a limit (the forecaster's own chance of this, stated with the estimate: 90%); middle value at least 1.2-fold (0.10 log units) from the limit.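

Compound 1, compound 2 and compound 4 are all reported only as limits, so neither step into compound 4 can be read. The compounds shown leave open where any of their actual values lie, and whether pyridin-2-yl in place of phenyl changes the tolerated concentration at all.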